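The source may hold more compounds than are shown below. What is called first, only, known or untested is meant among the compounds shown, and "the series" means these compounds.

Measured compounds:
compound 1 `CC(=O)c1ccc(OCc2ccccc2[N+](=O)[O-])cc1` in an assay on isolated protein for inhibition of Amine oxidase [flavin-containing] B (Homo sapiens), read by Amplex Red, with a stated time of 15 min; on this read-out lower numbers stand for stronger inhibition and higher numbers for weaker inhibition: 284 nM
compound 2 `CC(=O)c1ccc(OCc2ccccc2C(F)(F)F)cc1`: 183 nM
compound 3 `CC(=O)c1cccc(OCc2cccc(C(F)(F)F)c2)c1`: 21.2 nM

Compound 1 and compound 2 share a core, and the step between them, a 1.6-fold higher number from compound 2 to compound 1 (0.19 log units; within the scatter), follows from the change (nitro in place of trifluoromethyl on an aromatic carbon). Compound 3 is built on a different core from compound 2; the difference between the two cores is not broken down here. Compound 3 carries the lowest of the three numbers, and its gap to compound 2 and to compound 1 lies beyond the scatter in each case.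

Compound 4 `CC(=O)c1cccc(OCc2cccc([N+](=O)[O-])c2)c1` has not yet been measured. It differs from compound 3 by nitro in place of trifluoromethyl on an aromatic carbon. Among the measured compounds shown here, this is the same kind of change as the one from compound 2 to compound 1, but not the same: there the nitro sits ortho to a large group, here meta to a large group. Because the earlier step of a 1.6-fold higher number from compound 2 to compound 1 (0.19 log units; within the scatter) lies within the scatter, the expected step is a 1.5-fold higher number from compound 3 to compound 4 (0.18 log units; within the scatter). Compound 4 is therefore estimated at 32 nM in this assay, with a likely range from 12 nM to 85 nM.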

Compound 4, half-maximal inhibitory concentration: 114 nM
Compound 4: the middle estimate sits 3.6-fold (0.55 log units) below what was measured; the measured number lies above the stated range.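

In this assay, nitro in place of trifluoromethyl, here meta to a large group, gives a 5.4-fold higher number from compound 3 to compound 4 (0.73 log units; beyond the scatter), and this step does not match the one seen on the other core: the same change on two cores in this assay, a 1.6-fold higher number (0.19 log units; within the scatter) from compound 2 to compound 1 and a 5.4-fold higher number (0.73 log units; beyond the scatter) from compound 3 to compound 4, 3.5-fold (0.54 log units) apart, beyond the scatter of two such steps Within these four compounds, then, the size of the step does not carry over from one core to the other, and a step within the scatter on one core proved no safe guide to the step on the other. The two pairs do not show which feature of the cores sets the steps apart, as the difference between the cores is not broken down, and they say nothing about how the same change would behave on any third core.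

The compounds shown leave open whether other groups in the place of trifluoromethyl, such as a nitrile or a methoxy group, would also give steps that differ between the two cores. They also leave open how an amine or a carboxylic acid at that place would fare on either core.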